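Swapping the Imidazole at the Branch Point

The source may hold more compounds than are shown below. What is called first, only, known or untested is meant among the compounds shown, and "the series" means these compounds.

Compound 1 `CC(C)C(c1ncc[nH]1)c1ccc(-c2ccc3cccc(F)c3c2)[nH]c1=O` carries a 1H-imidazol-2-yl group on a saturated chain carbon bound to an aromatic carbon and a saturated chain carbon. In an assay on CHO cells for displacement of a labelled ligand from prostaglandin E2 receptor EP3 subtype (Homo sapiens), read by radioligand binding (on this read-out higher numbers stand for weaker inhibition and lower numbers for stronger inhibition), compound 1 gives 7.3 nM. Two companions differ from it only at that carbon. Compound 2 `CC(C)NC(=O)CC(c1ccc(-c2ccc3cccc(F)c3c2)[nH]c1=O)C(C)C` gives 5.8 nM, and compound 3 `CC(C)C(c1ccc(-c2ccc3cccc(F)c3c2)[nH]c1=O)N1CCCCC1=O` gives 6.4 nM. On these numbers compound 1 has the highest of the three, but all three lie within the usual scatter of one another: a 1.3-fold lower number from compound 1 to compound 2 (0.10 log units; within the scatter) and a 1.1-fold lower number from compound 1 to compound 3 (0.06 log units; within the scatter). Between the two companions, a 1.1-fold higher number from compound 2 to compound 3 (0.04 log units; within the scatter). Three quite different groups at this position thus leave the read-out within the scatter.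

Compound 4 `CC(C)C(c1cnc(N)s1)c1ccc(-c2ccc3cccc(F)c3c2)[nH]c1=O` is not yet measured. It differs from compound 1 as follows: 2-amino-1,3-thiazol-5-yl in place of 1H-imidazol-2-yl on a saturated chain carbon bound to an aromatic carbon and a saturated chain carbon. Both measured steps at this position, from compound 1 to compound 2 and from compound 1 to compound 3, stayed within the scatter, so a step of similar size is expected for compound 4 in this assay, with no direction beyond the scatter. The step expected is a 1.0-fold lower number from compound 1 to compound 4 (0.02 log units; within the scatter). Compound 4 is therefore estimated at 7 nM, with a range from 3 nM to 16 nM.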

Compound 4, inhibition constant: 16 nM
For compound 4 the middle estimate is 2.3-fold (0.36 log units) below the measured one; low and high end bracket the measured number.
By their numbers in this assay, from the lowest: compounds 2, 3 and 1 (each within the scatter of the next); then compound 4.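

Up to this point the saturated chain carbon seemed to accept almost anything, yet 2-amino-1,3-thiazol-5-yl is the first group here that moves the number in this assay beyond the scatter, with a 2.2-fold higher number from compound 1 to compound 4 (0.34 log units; beyond the scatter) and a 2.5-fold higher number from compound 3 to compound 4 (0.40 log units; beyond the scatter) and also a 2.8-fold higher number from compound 2 to compound 4 (0.44 log units; beyond the scatter). The position therefore does respond to the group it carries, though these steps are modest, and the change keeps one five-membered aromatic ring with 2 hetero atoms while bringing in sulfur and an amino group, so keeping that ring type does not by itself hold the number level. Nothing measured here accounts for the shift.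

The compounds shown do not separate the sulfur from the amino group, and a plain 1,3-thiazol-5-yl without the amine would pull the two apart. Going by these compounds, it also remains open how a carboxylic acid or a simple primary amine on this carbon would read out, and whether any group here can give a clearly lower number than the three that sit together.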